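The compounds below may be only part of what the source reports. "The series", "measured", "known", "first", "only" and "open" are said of these compounds alone.

Measured so far, in an assay on isolated protein for inhibition of high affinity 3',5'-cyclic-AMP phosphodiesterase 7A (Homo sapiens), read by scintillation proximity assay and cAMP accumulation, with a stated time of 20 min, tested at 10 uM; a higher number here means more inhibition at the concentration tested (going by the name of the read-out), a lower number less inhibition:
compound 1, `COc1cc(COC(=O)c2ccc(-c3ccc(Cl)cc3Cl)o2)cc(OC)c1OC`, gives 38.3%
compound 2, `COc1cc(COC(=O)c2ccc(-c3ccc(C)cc3)o2)cc(OC)c1OC`, gives 30.7%
compound 3, `CCOc1cc(COC(=O)c2ccc(-c3ccc(Cl)cc3Cl)o2)cc(OCC)c1OCC`, gives 31.1%

Compound 1 and compound 2 share a core and differ in one place: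

4-methylphenyl in place of 2,4-dichlorophenyl on an aromatic carbon

This change gave a number 7.6 percentage points lower from compound 1 to compound 2 (within the scatter). Compound 3 carries a different core; the difference between the two cores is not broken down here. Compound 4, `CCOc1cc(COC(=O)c2ccc(-c3ccc(C)cc3)o2)cc(OCC)c1OCC`, is built from compound 3 by the same change:

4-methylphenyl in place of 2,4-dichlorophenyl on an aromatic carbon

Since the place is described in the same words in both cases, this is the same change made on the other core. Because a number 7.6 percentage points lower from compound 1 to compound 2 (within the scatter) stayed within the scatter, only a small step is expected here as well, a number 7.1 percentage points lower from compound 3 to compound 4 (within the scatter). Compound 4 is therefore estimated at 24%, most likely between 11% and 37%.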

Compound 4, a percentage reported as inhibition, at one concentration (the size of the read-out at that concentration, not a potency): 28%
The estimate for compound 4 lay 4 percentage points below the measured number; the range from low to high includes it.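

In this assay, putting 4-methylphenyl in place of 2,4-dichlorophenyl gave a number 3.1 percentage points lower from compound 3 to compound 4 (within the scatter). Set beside the earlier step, the change looks alike on the two cores: the same change on two cores in this assay, a number 7.6 percentage points lower (within the scatter) from compound 1 to compound 2 and a number 3.1 percentage points lower (within the scatter) from compound 3 to compound 4, 4.5 percentage points apart, within the scatter of two such steps. Among the compounds shown here, both steps are small, so this shows only that the swap did little on either core; it does not show that a change with a larger effect would carry across these cores in the same way.

The compounds shown leave open what a quite different group in this place, such as an amine or a carboxylic acid, would do. They also leave open whether a longer chain in place of the ethoxy groups would move the inhibition at all.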